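Dichlorination of the benzyl group in a cyclic sulfonamide series

The source may hold more compounds than are shown below. What is called first, only, known or untested is meant among the compounds shown, and "the series" means these compounds.

Measured so far:
compound 1 `O=C1c2ccccc2N(COCc2ccccc2)S(=O)(=O)N1Cc1ccccc1`: 25000 nM
compound 2 `O=C1c2ccccc2N(Cc2ccccc2)S(=O)(=O)N1Cc1ccccc1`: 108000 nM

In a functional assay on CCRF-CEM cells (Homo sapiens) for inhibition (on this read-out lower numbers stand for higher toxicity in this test and higher numbers for lower toxicity in this test), compound 2 gives 108000 nM, the higher of the two numbers; the nearest is compound 1, and the step of a 4.3-fold higher number from compound 1 to compound 2 (0.64 log units; beyond the scatter) lies beyond the scatter. Compound 3 `O=C1c2ccccc2N(Cc2ccc(Cl)c(Cl)c2)S(=O)(=O)N1Cc1ccccc1` differs from compound 2 by 3,4-dichlorophenyl in place of phenyl on a saturated chain carbon bound to a sulfonamide nitrogen in a ring. For the measured compounds named here, no measured step changes a substituent on this phenyl ring; the only step known, a 4.3-fold higher number from compound 1 to compound 2 (0.64 log units; beyond the scatter), exchanges the whole group at this position and so bears on the new step only loosely, showing that this carbon tolerates modest changes in either direction. With nothing closer to go on, compound 3 is expected to sit somewhat below compound 2, a step of a 2.4-fold lower number from compound 2 to compound 3 (0.38 log units; beyond the scatter), with wide uncertainty. Compound 3 is therefore estimated at 45000 nM, between 12000 nM and 160000 nM.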

Compound 3, half-maximal cytotoxic concentration: 16400 nM
Estimate against measurement, compound 3: 2.7-fold (0.44 log units) above; the range from low to high includes it.
By their numbers in this assay, from the lowest: compounds 3 and 1 (each within the scatter of the next); then compound 2.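

In this assay, the change from benzyl to 3,4-dichlorobenzyl (read as a 6.6-fold lower number from compound 2 to compound 3 (0.82 log units; beyond the scatter)) shows that substituents on this phenyl ring can shift the number beyond the scatter, whereas the earlier step exchanged the whole group. The step to the benzyloxy compound (a 1.5-fold lower number from compound 1 to compound 3 (0.18 log units; within the scatter)) lies within the scatter, so 3,4-dichlorophenyl and benzyloxy at this chain carbon give numbers that cannot be told apart, and compound 2, with its unsubstituted phenyl, alone stands higher than both. Nothing available here explains this result.

The compounds shown leave open whether a single chlorine on the benzyl ring would give the same step, and whether a methoxy group or a carboxylic acid there would behave like the two chlorines. They also leave open whether the same change would carry over if the other benzyl group on the shared core were replaced.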